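Replacing fluoro with iodo on a potent cytotoxic compound

The compounds below may be only part of what the source reports. "The series", "measured", "known", "first", "only" and "open" are said of these compounds alone.

In a functional assay on MCF7 cells (Homo sapiens) for cytotoxicity, read by MTT assay, with a stated time of 48 h (a lower number here means a stronger inhibitor, a higher number a weaker inhibitor), compound 1 `C/C(=N\NC(=S)Nc1cccc(F)c1)c1ccccn1` gives 9 nM and stands level with compound 2 `CC(=NNC(=S)Nc1cccc(F)c1)c1ccccn1`, which gives 9 nM. Within the data shown here, the only measured step, no change at the digits printed from compound 1 to compound 2 (within the scatter), comes with the fact that one of compounds 1 and 2 is drawn with a defined configuration and the other without, at the place where they differ and leaves the halogen untouched. Compound 3 `C/C(=N\NC(=S)Nc1cccc(I)c1)c1ccccn1` differs from compound 1 by iodo in place of fluoro on an aromatic carbon, on an aromatic carbon, meta to a large group. Among the measured compounds shown here, no measured step covers a halogen exchange, so the expectation stays near compound 1 at 9 nM. A slight weakening is expected, a 1.7-fold higher number from compound 1 to compound 3 (0.22 log units; within the scatter) in this assay. The value expected for compound 3 is 15 nM, with an estimated range of 4 nM to 60 nM.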

Compound 3, half-maximal inhibitory concentration: 45 nM
Beside the measured number, compound 3's estimate is 3.0-fold (0.48 log units) below it, within the range that was stated.
By their numbers in this assay, from the lowest: compounds 1 and 2 (each within the scatter of the next); then compound 3.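

In this assay the halogen on this aromatic carbon proves not to be a free choice: iodo in place of fluoro gives a 5.0-fold higher number from compound 1 to compound 3 (0.70 log units; beyond the scatter) and so costs some potency, something the earlier pair could not show, as it left the halogen untouched. Compound 3 nevertheless keeps a low value of 45 nM in this assay. Nothing available bears on why this step occurs. Still open, on these data alone, is how chloro, bromo, methyl or methoxy on the same aromatic carbon would read, and whether iodo would give a similar step elsewhere on the ring.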